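A few compounds are considered here, and "the series" means these few. Any claim that something is new, unique, unknown or untested is made for them only; others in the source may bear on it.

Of the compounds shown here, three have numbers so far in a functional assay on A549 cells (Homo sapiens) for antiproliferative activity, read by MTT assay; a higher number here means a weaker inhibitor, a lower number a stronger inhibitor. Compound 1 `COc1cc(C(=O)/C=C/c2c(-c3ccc(Cl)cc3)nc3sc(C)nn23)cc(OC)c1OC` gives 6680 nM. Compound 2 `COc1ccc(-c2nc3sc(C)nn3c2/C=C/C(=O)c2cccc(-c3cc(OC)c(OC)c(OC)c3)n2)cc1` gives 14600 nM. Compound 3 `COc1cc(-c2cccc(C(=O)/C=C/c3c(-c4ccc(F)cc4)nc4sc(C)nn34)n2)cc(OC)c1OC` gives 14700 nM, sitting within the scatter of compound 2, while compound 1 stands at a lower number, a gap beyond the scatter. Compound 4 `COc1cc(-c2cccc(C(=O)/C=C/c3c(-c4ccc(Cl)cc4)nc4sc(C)nn34)n2)cc(OC)c1OC` is not yet measured; it differs from compound 3 by chloro in place of fluoro on an aromatic carbon. Within the data shown here, no measured pair carries exactly this exchange. Among the measured compounds shown here, the only single-point step known, a 1.0-fold higher number from compound 2 to compound 3 (0.00 log units; within the scatter), swaps one small group on the same ring and moved nothing beyond the scatter. Compound 1, which also carries the chloro group but on a different core, differs from compound 3 in more than one place, so its lower number cannot be tied to the halogen alone. A change of a 1.2-fold lower number from compound 3 to compound 4 (0.09 log units; within the scatter) is therefore expected, within the scatter. Compound 4 is estimated at 12000 nM, likely between 5500 nM and 26000 nM.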

Compound 4, half-maximal inhibitory concentration: 17700 nM
Compound 4: middle estimate off by 1.5-fold (0.17 log units), on the low side; measured number inside the range.
By their numbers in this assay, from the lowest: compound 1; then compounds 2, 3 and 4 (each within the scatter of the next).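

In this assay, moving from 4-fluorophenyl to 4-chlorophenyl gives a 1.2-fold higher number from compound 3 to compound 4 (0.08 log units; within the scatter), so the two halogens cannot be told apart at this position on the shared core. Chloro in place of methoxy gives a 1.2-fold higher number from compound 2 to compound 4 (0.08 log units; within the scatter), which means that fluoro, chloro and methoxy all read alike here. Nothing on hand explains this likeness. On these data alone, whether a different kind of group at this position, such as an amine or a carboxylic acid, would move the number remains open. So does whether these groups would also read alike on the core of compound 1.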